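A few compounds are considered here, and "the series" means these few. Any claim that something is new, unique, unknown or untested is made for them only; others in the source may bear on it.

Series notes. Compound 1 `CCC1=C(O)c2c(oc(-c3ccc(C(F)(F)F)cc3)cc2=O)C(CC)(CC)C1=O` and compound 2 `CCC1=C(O)c2c(oc(-c3ccc(OC)cc3)cc2=O)C(CC)(CC)C1=O` share one core; compound 3 `CCC1=C(O)c2c(oc(-c3ccccc3C(F)(F)F)cc2=O)C(CC)(CC)C1=O` and compound 4 `CCC1=C(O)c2c(oc(-c3ccccc3OC)cc2=O)C(CC)(CC)C1=O` share another, and the difference between the two cores is not broken down here.

In a functional assay on KBVIN cells (Homo sapiens) for antiproliferative activity, read by sulforhodamine B assay, with a stated time of 3 days (a lower number here means that less compound is needed, a higher number that more compound is needed for the effect), compound 1 gives 10.4 uM, while compound 2 gives 0.68 uM. The change between them is methoxy in place of trifluoromethyl on an aromatic carbon and it produced a 15-fold lower number from compound 1 to compound 2 (1.18 log units; beyond the scatter). Compound 3 gives 43.1 uM in this assay, the highest number of the three measured, beyond the scatter from both compound 1 and compound 2.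

Compound 4 is unmeasured. It carries methoxy in place of trifluoromethyl on an aromatic carbon, which is the same kind of change as that from compound 1 to compound 2, not the same one: there the methoxy sits para to a large group, here ortho to a large group.

Expectation for compound 4 in this assay: a step of about an 8.6-fold lower number from compound 3 to compound 4 (0.94 log units; beyond the scatter) is estimated, somewhat smaller than the measured step from compound 1 to compound 2, because a 15-fold lower number from compound 1 to compound 2 (1.18 log units; beyond the scatter) was recorded at a different place on the ring and only one such pair exists. The estimated value for compound 4 is 5 uM, with a range from 1.5 uM to 16 uM.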

Compound 4, concentration for half-maximal effect: 3.26 uM
Estimate against measurement, compound 4: 1.5-fold (0.19 log units) above, within the range that was stated.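

In this assay, methoxy in place of trifluoromethyl on the aromatic carbon ortho to a large group gives a 13-fold lower number from compound 3 to compound 4 (1.12 log units; beyond the scatter). Set beside the earlier pair, the swap carries from one core to the other with its size unchanged within the scatter: the same change on two cores in this assay, a 15-fold lower number (1.18 log units; beyond the scatter) from compound 1 to compound 2 and a 13-fold lower number (1.12 log units; beyond the scatter) from compound 3 to compound 4, 1.2-fold (0.06 log units) apart, within the scatter of two such steps. Among the compounds shown here, this rests on only two pairs, so it shows agreement for this one swap on these two cores and no general rule for other groups or cores, and the two steps do not make the position of the methoxy irrelevant, since 2-methoxyphenyl in place of 4-methoxyphenyl gives a 4.8-fold higher number from compound 2 to compound 4 (0.68 log units; beyond the scatter).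

From the compounds shown here alone, it remains open whether the same step would appear if a hydroxyl, an amine or a carboxylic acid took the place of the methoxy on the aromatic ring. Going by these compounds, it is also open whether the step would hold on a core carrying a longer chain.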